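The source may report more compounds than this note shows. Statements on the series, on what has been measured and on what is new or still open speak of the compounds shown alone.

Working notes on the series. The parent is compound 1, `COc1ccc(-c2csc(N/N=C/c3ccc(-n4ccnc4)cc3)n2)cc1`; in an ADME assay on THP-1 cells (Homo sapiens) for cytotoxicity, read by MTT assay, tested at 50 ug/mL (a lower number here means less inhibition, a higher number more inhibition at the concentration tested (going by the name of the read-out)), compound 1 gives 26.8%. Compound 2, `O=[N+]([O-])c1ccc(-c2csc(N/N=C/c3ccc(-n4ccnc4)cc3)n2)cc1`, carries the change nitro in place of methoxy on an aromatic carbon and in this assay compound 2 gives 16.4%, which is a number 10.4 percentage points lower from compound 1 to compound 2 (beyond the scatter). Compound 3, `COc1ccc(-c2csc(N/N=C/c3ccc(-n4cncn4)cc3)n2)cc1`, differs from compound 1 by 1H-1,2,4-triazol-1-yl in place of 1H-imidazol-1-yl on an aromatic carbon; in this assay compound 3 gives 23%, a move of a number 3.8 percentage points lower from compound 1 to compound 3 (within the scatter), so compound 1 and compound 3 are not told apart here.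

Compound 4, `O=[N+]([O-])c1ccc(-c2csc(N/N=C/c3ccc(-n4cncn4)cc3)n2)cc1`, is not yet measured. It stands to compound 3 as compound 2 stands to compound 1: the change is nitro in place of methoxy on an aromatic carbon, the same change made twice among these compounds, with the place the same word for word both times. The two cores differ by 1H-1,2,4-triazol-1-yl in place of 1H-imidazol-1-yl on an aromatic carbon.

Going by the values given here, the single earlier instance of this change is a number 10.4 percentage points lower from compound 1 to compound 2 (beyond the scatter). Because that step is a number 10.4 percentage points lower from compound 1 to compound 2 (beyond the scatter) and compound 3 sits at 23%, the step from compound 3 to compound 4 is expected to be a number 10 percentage points lower from compound 3 to compound 4 (within the scatter) in this assay, carrying the same sign and about the same size, though one instance is a thin basis. Compound 4 is therefore estimated at 13% in this assay, with a likely span from 3% to 24%.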

Compound 4, a percentage reported as inhibition, at one concentration (the size of the read-out at that concentration, not a potency): 12.9%
Compound 4: middle estimate off by 0.1 percentage points, on the high side; the measured number falls inside the stated range.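

In this assay, nitro in place of methoxy behaves alike on both cores, the new step being a number 10.1 percentage points lower from compound 3 to compound 4 (beyond the scatter) and matching the earlier one: the same change on two cores in this assay, a number 10.4 percentage points lower (beyond the scatter) from compound 1 to compound 2 and a number 10.1 percentage points lower (beyond the scatter) from compound 3 to compound 4, 0.3 percentage points apart, within the scatter of two such steps.

With nitro in place, 1H-1,2,4-triazol-1-yl in place of 1H-imidazol-1-yl gives a number 3.5 percentage points lower from compound 2 to compound 4 (within the scatter), leaving that pair not told apart and agreeing with the same change under methoxy: the same change on two cores in this assay, a number 3.8 percentage points lower (within the scatter) from compound 1 to compound 3 and a number 3.5 percentage points lower (within the scatter) from compound 2 to compound 4, 0.3 percentage points apart, within the scatter of two such steps.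

Going by these compounds alone, this shows that the two changes add up across these four compounds at one tested concentration, but it rests on only two cores and one pair of groups, so it does not establish that the nitro step would carry to any other core, and it gives no reason for the step.

The compounds shown leave open how an amine, a carboxylic acid or a longer chain would read on the same aromatic carbon in place of methoxy or nitro. Also open, from the compounds shown here alone, is whether the step survives on a core carrying a group other than 1H-imidazol-1-yl or 1H-1,2,4-triazol-1-yl.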